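This account rests on a few compounds, and the source may have more. Where it says the series, first, only, none or still open, it means among the compounds named here.

Measured so far in a functional assay on A549 cells (Homo sapiens) for antiproliferative activity, read by MTT assay, with a stated time of 72 h; on this read-out lower numbers stand for stronger inhibition and higher numbers for weaker inhibition
- compound 1 `CC/C=C/C(=O)Nc1cccc(Oc2nc(Nc3ccn(C)n3)nc3c2CSCC3)c1` gives 36800 nM
- compound 2 `CC(C)=CC(=O)Nc1cccc(Oc2nc(Nc3ccn(C)n3)nc3c2CSCC3)c1` gives 44200 nM

Going by the values given here, compound 2 stands level with compound 1, the only other number. Compound 3 `C=C(F)C(=O)Nc1cccc(Oc2nc(Nc3ccn(C)n3)nc3c2CSCC3)c1` carries 1-fluoroethenyl in place of 2-methylprop-1-en-1-yl on a carbonyl carbon. Among the compounds with values here, the one measured step at this place (a 1.2-fold higher number from compound 1 to compound 2 (0.08 log units; within the scatter)) stays within the scatter, but it does not involve 1-fluoroethenyl, so it sets only a weak guide. In this assay a modest move to a lower number is expected, with the estimated step being a 2.5-fold lower number from compound 2 to compound 3 (0.39 log units; beyond the scatter) and its size uncertain. Compound 3 is estimated at 18000 nM, with an expected range from 4000 nM to 55000 nM.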

Compound 3, half-maximal inhibitory concentration: > 50000 nM
Compound 3: a limit, no number; the forecaster's own chance of this, stated with the estimate: 10%; middle value at least 2.7-fold (0.44 log units) from the limit.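

In this assay compound 3 gives > 50000 nM, which is a limit of the assay and not a number. Going by these compounds, with 1-fluoroethenyl on this carbonyl carbon, the readable steps are an at least 1.1-fold higher number from compound 2 to compound 3 (0.05 log units; that floor lies within the scatter) and an at least 1.3-fold higher number from compound 1 to compound 3 (0.13 log units; that floor lies within the scatter), so this change brings no lower number, while the true size of the rise stays unknown. The series now reaches the top of the measurable range: the limit of > 50000 nM in this assay, at which 1 of the 3 values shown sits.

Still open, on these data alone, is whether a plain ethenyl group, or a dimethylamino group on the alkenyl chain, would bring the number down at this place. Also open, as far as these compounds go, is whether any group on this carbonyl carbon gives strong inhibition on the shared core.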